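This account rests on a few compounds, and the source may have more. Where it says the series, first, only, none or still open, it means among the compounds named here.

Compound 2 `c1ccc(COc2cccc(-c3cn([C@H]4CN5CCC4CC5)nn3)c2)cc1` is the single-enantiomer compound of this pair, and in an assay on HEK293 cells for displacement of a labelled ligand from Neuronal acetylcholine receptor; alpha3/beta4 (Homo sapiens), read by scintillation counting, with a stated time of 120 min (on this read-out higher numbers stand for weaker inhibition and lower numbers for stronger inhibition), compound 2 gives 631 nM, the higher of the two numbers recorded. Compound 1 `Fc1ccc(COc2cccc(-c3cn(C4CN5CCC4CC5)nn3)c2)cc1`, which carries a fluorine on its benzyl ring, gives 13.9 nM in this assay, a gap well beyond the usual scatter. Compound 3 `Fc1ccc(COc2cccc(-c3cn([C@H]4CN5CCC4CC5)nn3)c2)cc1` has not yet been measured; it arises from compound 2 by fluoro in place of hydrogen on an aromatic carbon. Because compound 1 shows 13.9 nM with that same fluorine in place, a sizeable drop is expected here, estimated at a 21-fold lower number from compound 2 to compound 3 (1.32 log units; beyond the scatter). Compound 3 is therefore expected to give about 30 nM, plausibly between 8 nM and 150 nM.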

Compound 3, inhibition constant: 1090 nM
Compound 3: the middle estimate sits 36-fold (1.56 log units) below what was measured, outside the stated range (above it).
By their numbers in this assay, from the lowest: compound 1; then compounds 2 and 3 (each within the scatter of the next).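

With the saturated ring carbon drawn the same way in both, fluoro in place of hydrogen gives a 1.7-fold higher number from compound 2 to compound 3 (0.24 log units; within the scatter) and so makes no readable difference at this aromatic carbon. The large gap appears instead as a 78-fold higher number from compound 1 to compound 3 (1.89 log units; beyond the scatter) between two compounds with the same atoms and bonds, so it goes with the stereocentre and not with the fluoro group: the fact that one of compounds 1 and 3 is drawn with a defined configuration and the other without, at the place where they differ. Still open, going by these compounds, is how the S form of compound 3 would read, and whether chloro or methoxy on the same aromatic carbon would also leave the number unchanged.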